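Chalcone-pyrazole series: trimethoxyphenyl completion on the second aryl

This account rests on a few compounds, and the source may have more. Where it says the series, first, only, none or still open, it means among the compounds named here.

Three compounds of the series have been run in a functional assay on T47D cells (Homo sapiens) for inhibition, read by sulforhodamine B assay, with a stated time of 48 h; a higher number here means a weaker inhibitor of growth, a lower number a stronger inhibitor of growth. Compound 1 `COc1cc(-c2cc(/C=C/C(=O)c3ccc(N)cc3)[nH]n2)cc(OC)c1OC` gives 4300 nM, compound 2 `COc1ccc(C(=O)/C=C/c2cc(-c3cc(OC)c(OC)c(OC)c3)n[nH]2)cc1OC` gives 4360 nM and compound 3 `COc1ccc(-c2cc(/C=C/C(=O)c3ccc(N)cc3)[nH]n2)cc1OC` gives 26000 nM. The change from compound 3 to compound 1 is methoxy in place of hydrogen on an aromatic carbon and brought a 6.0-fold lower number from compound 3 to compound 1 (0.78 log units; beyond the scatter). The change from compound 1 to compound 2 brought a 1.0-fold higher number from compound 1 to compound 2 (0.01 log units; within the scatter). How the cores of compound 2 and compound 3 differ is not broken down here.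

Compound 4 `COc1cc(C(=O)/C=C/c2cc(-c3cc(OC)c(OC)c(OC)c3)n[nH]2)cc(OC)c1OC` is not yet measured. It differs from compound 2 by methoxy in place of hydrogen on an aromatic carbon, the same change as that from compound 3 to compound 1, made at a place described in the same words. In this assay compound 4 is therefore expected to show a step of about a 5.8-fold lower number from compound 2 to compound 4 (0.76 log units; beyond the scatter), resting on the step of a 6.0-fold lower number from compound 3 to compound 1 (0.78 log units; beyond the scatter) seen between compound 3 and compound 1. The expected value for compound 4 is 750 nM, with a range estimated from 300 nM to 2200 nM.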

Compound 4, concentration for total growth inhibition: 2570 nM
Beside the measured number, compound 4's estimate is 3.4-fold (0.53 log units) below it, and the stated range ends below it.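

In this assay, methoxy in place of hydrogen on an aromatic carbon gave a 1.7-fold lower number from compound 2 to compound 4 (0.23 log units; within the scatter), so the clear step seen on the core of compound 1 did not recur at the same size here. The same change therefore does not carry over with one size across these two cores: the same change on two cores in this assay, a 6.0-fold lower number (0.78 log units; beyond the scatter) from compound 3 to compound 1 and a 1.7-fold lower number (0.23 log units; within the scatter) from compound 2 to compound 4, 3.6-fold (0.55 log units) apart, beyond the scatter of two such steps. This shows that the size of the step depended on the core in these two pairs, but it does not show why, and two pairs set no rule for the rest of the series.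

Going by these compounds, it remains open whether a hydroxyl group or a chlorine atom in place of that hydrogen would give a step that also depends on the core. On these data alone, the size of the methoxy step on any third core also remains open.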